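Allyloxy and benzyloxy aminoquinoline analogues: cytotoxicity notes

A few compounds are considered here, and "the series" means these few. Any claim that something is new, unique, unknown or untested is made for them only; others in the source may bear on it.

Compound 1 `C=CCOc1ccc2c(NCCCN(C)C)ccnc2c1` gives 2100 nM in a functional assay on HCT-116 cells (Homo sapiens) for cytotoxicity, read by MTT assay, with a stated time of 48 h; on this read-out higher numbers stand for weaker inhibition and lower numbers for stronger inhibition.
Compound 2 `CN(C)CCNc1ccnc2cc(OCc3ccc(F)cc3)ccc12` gives 370 nM in this assay.
Compound 3 `CN(C)CCNc1ccnc2cc(OCc3ccccc3)ccc12` gives 1980 nM in this assay.

Compound 3 stands second highest of the three numbers in this assay. Its nearest neighbour is compound 1, whose value sits within the scatter of that of compound 3, so no order between these two is claimed. Going by the values given here, the only step measured so far is a 5.4-fold higher number from compound 2 to compound 3 (0.73 log units; beyond the scatter), a change on the aromatic ring of the benzyloxy group that does not touch the part altered here.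

Compound 4 `C=CCOc1ccc2c(NCCN(C)C)ccnc2c1` is not yet measured. It differs from compound 3 in one place: vinyl in place of phenyl on a saturated chain carbon bound to an oxygen on an aromatic ring. Among the compounds with values here, no measured step bears on this change directly. Compound 1 carries the same allyloxy group as compound 4 and its value is within the scatter of that of compound 3, though compound 1 also differs from both in the length of the amine chain, so that comparison is indirect. On this basis, the step of a 1.0-fold higher number from compound 3 to compound 4 (0.00 log units; within the scatter) is expected to stay within the scatter, with no clear direction. Compound 4 is therefore estimated at 2000 nM, with a range from 900 nM to 4500 nM in this assay.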

Compound 4, half-maximal inhibitory concentration in the HCT-116 assay: 860 nM
Estimate against measurement, compound 4: 2.3-fold (0.37 log units) above; the whole stated range lies above it.
By their numbers in the HCT-116 assay, from the lowest: compound 2; then compound 4; then compounds 3 and 1 (each within the scatter of the next).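

Working notes on the series: in the HCT-116 assay the change from benzyloxy to allyloxy is not neutral, since a 2.3-fold lower number from compound 3 to compound 4 (0.36 log units; beyond the scatter) shows that the phenyl is not needed for a lower number at this position, while a 2.3-fold higher number from compound 2 to compound 4 (0.37 log units; beyond the scatter) shows that the allyloxy group does not match the 4-fluorophenyl version of the benzyl group. With the allyloxy group held, the amine chain counts as well: a 2.4-fold lower number from compound 1 to compound 4 (0.39 log units; beyond the scatter) follows from dimethylamino in place of (dimethylamino)methyl on a saturated chain carbon, two bonds along the chain from a nitrogen on an aromatic ring. In a physicochemical assay for solubility (on this read-out lower numbers stand for lower solubility and higher numbers for higher solubility), compound 3 gives > 10000 ug/mL as a limit of the assay.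

In the physicochemical assay compound 4 gives > 10000 ug/mL as a limit too, so the step from the benzyloxy to the allyloxy compound cannot be read: the limit of > 10000 ug/mL in the physicochemical assay, at which 2 of the 2 values shown sit.
Still open, going by these compounds, is how a propyloxy or a methoxy group would read at this position in the HCT-116 assay and whether a pyrrolidine in place of the dimethylamino group would keep the number of compound 4 unchanged.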